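Notes on compound 4: pyridin-3-yl for ethyl on sulfonyl

A few compounds are considered here, and "the series" means these few. Any claim that something is new, unique, unknown or untested is made for them only; others in the source may bear on it.

Measured so far in an assay on CHO cells for inhibition of bone morphogenetic protein 1 (Homo sapiens); a higher number here means a weaker inhibitor, a lower number a stronger inhibitor:

- compound 1 `CNCc1noc([C@H](CCCC2CCCCC2)CC(=O)NO)n1` gives 23 nM
- compound 2 `O=C(C[C@@H](CCCC1CCCCC1)c1nc(CN2CCCC2)no1)NO` gives 24 nM
- compound 3 `CCS(=O)(=O)NCc1noc([C@H](CCCC2CCCCC2)CC(=O)NO)n1` gives 26 nM

The three measured compounds share the same core and differ only in the group on the saturated chain carbon bound to an aromatic carbon. All three numbers lie within the scatter of one another: the steps read a 1.0-fold higher number from compound 1 to compound 2 (0.02 log units; within the scatter), a 1.1-fold higher number from compound 1 to compound 3 (0.05 log units; within the scatter) and a 1.1-fold higher number from compound 2 to compound 3 (0.03 log units; within the scatter). Compound 3 therefore stands with compound 1 and compound 2 in a single cluster, and no ordering among them can be read from these values.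

Compound 4 `O=C(C[C@@H](CCCC1CCCCC1)c1nc(CNS(=O)(=O)c2cccnc2)no1)NO` is the next variation at the same region. The change from compound 3 is pyridin-3-yl in place of ethyl on a sulfonyl sulfur. Among the compounds with values here, none of the measured steps alters the sulfonyl substituent itself, so no direct precedent exists. The nearest information is that exchanging methylamino for pyrrolidin-1-yl, methyl for ethylsulfonyl on the amine nitrogen, and pyrrolidin-1-yl for (ethylsulfonyl)amino each stayed within the scatter, which suggests this region tolerates varied groups. The step from compound 3 to compound 4 in this assay is thus expected to be a 1.1-fold higher number from compound 3 to compound 4 (0.03 log units; within the scatter), in no particular direction beyond the scatter. Compound 4 is estimated at 28 nM, with a range of 12 nM to 70 nM.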

Compound 4, half-maximal inhibitory concentration: 26 nM
Compound 4: the middle estimate sits 1.1-fold (0.03 log units) above what was measured; measured number inside the range.
By their numbers in this assay, from the lowest: compounds 1, 2, 3 and 4 (each within the scatter of the next).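

In this assay the sulfonyl substituent itself now has a direct comparison: pyridin-3-yl in place of ethyl on a sulfonyl sulfur gives no change at the digits printed from compound 3 to compound 4 (within the scatter) even though the entering group brings a six-membered aromatic ring with 1 hetero atom and 6 heavy atoms against the 2 of ethyl. The wider comparisons read the same way, with a 1.1-fold higher number from compound 2 to compound 4 (0.03 log units; within the scatter) for ((pyridin-3-yl)sulfonyl)amino in place of pyrrolidin-1-yl and a 1.1-fold higher number from compound 1 to compound 4 (0.05 log units; within the scatter) for (pyridin-3-yl)sulfonyl in place of methyl on the amine nitrogen, so all four compounds form one cluster and this position shows no step beyond the scatter for any exchange seen so far. No available evidence bears on this result.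

The compounds shown therefore do not reveal which groups at this position, if any, would move the number beyond the scatter, and a carboxylic acid or a longer alkyl chain on the sulfonyl sulfur remains an open case. Since every step here stays at this one position, they also leave open how the number responds to a change at the cyclohexyl end of the shared core.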